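Cytotoxicity notes: amine substitution in a quinazoline-free shared core

The source may report more compounds than this note shows. Statements on the series, on what has been measured and on what is new or still open speak of the compounds shown alone.

Measured so far in an ADME assay on L6 cells (Rattus norvegicus) for cytotoxicity, read by fluorescence and resazurin assay, with a stated time of 70 h; on this read-out lower numbers stand for stronger inhibition and higher numbers for weaker inhibition:
compound 1 `COc1cc2nc(N3CCCC3)nc(N)c2cc1OC` gives 28200 nM
compound 2 `COc1cc2nc(N3CCCC3)nc(NC(C)C)c2cc1OC` gives 12500 nM

For the measured compounds named here, compound 2 holds the lower of the two numbers; the only step recorded is a 2.3-fold lower number from compound 1 to compound 2 (0.35 log units; beyond the scatter). Compound 3 `COc1cc2nc(N3CCCC3)nc(NCc3ccccc3)c2cc1OC` has not yet been measured in this assay. The change is benzyl in place of isopropyl on a nitrogen on an aromatic ring. Going by the values given here, the one step that bears on it is the move from hydrogen to isopropyl on the same nitrogen, which lowered the number modestly; the further enlargement is expected to continue in that direction, giving a 1.8-fold lower number from compound 2 to compound 3 (0.25 log units; within the scatter). For compound 3 the estimate is 7000 nM, within 2500 nM to 25000 nM.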

Compound 3, half-maximal inhibitory concentration: 9490 nM
Beside the measured number, compound 3's estimate is 1.4-fold (0.13 log units) below it; measured number inside the range.
By their numbers in this assay, from the lowest: compounds 3 and 2 (each within the scatter of the next); then compound 1.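

In this assay, a 1.3-fold lower number from compound 2 to compound 3 (0.12 log units; within the scatter) shows that exchanging isopropyl for benzyl on this nitrogen, with its six-membered aromatic ring, does not separate the two groups. Measured against hydrogen, benzyl gives a 3.0-fold lower number from compound 1 to compound 3 (0.47 log units; beyond the scatter), so both substituted compounds stand apart from compound 1 while the size of the shift stays modest. No evidence on the origin of this behaviour is available.

Still open, as far as these compounds go, is how a phenethyl group, a longer alkyl chain or a carboxylic acid on this nitrogen would read here. From the compounds shown here alone, whether substituents on the benzyl ring shift the number also remains unknown.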